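Moving the chloro series toward a methoxybenzyl ether

A few compounds are considered here, and "the series" means these few. Any claim that something is new, unique, unknown or untested is made for them only; others in the source may bear on it.

Compound 2 `FC(F)(F)c1ccc(CN2CCN(Cc3cc(-c4ccc(OCc5ccccc5Cl)cc4)on3)CC2)cc1` gives 2800 nM in a functional assay on MCF7 cells (Homo sapiens) for antiproliferative activity, read by sulforhodamine B assay, with a stated time of 72 h; a lower number here means a stronger inhibitor, a higher number a weaker inhibitor. Compound 1 `Cc1ccccc1COc1ccc(-c2cc(CN3CCN(Cc4ccc(C(F)(F)F)cc4)CC3)no2)cc1` gives 3700 nM, and compound 3 `FC(F)(F)c1ccc(CN2CCN(Cc3cc(-c4ccc(OCc5cccc(Cl)c5)cc4)on3)CC2)cc1` gives 1400 nM; compound 2 sits within the scatter of both, with a 1.3-fold lower number from compound 1 to compound 2 (0.12 log units; within the scatter) and a 2.0-fold lower number from compound 2 to compound 3 (0.30 log units; within the scatter). Among the measured compounds shown here, only the step of a 2.6-fold lower number from compound 1 to compound 3 (0.42 log units; beyond the scatter) reaches beyond the scatter. Compound 4 `COc1cccc(COc2ccc(-c3cc(CN4CCN(Cc5ccc(C(F)(F)F)cc5)CC4)no3)cc2)c1` differs from compound 2 by 3-methoxyphenyl in place of 2-chlorophenyl on a saturated chain carbon bound to an oxygen on an aromatic ring. For the measured compounds named here, the one step that bears on it, a 2.0-fold lower number from compound 2 to compound 3 (0.30 log units; within the scatter), concerns the same shift of a single substituent on that ring and stayed within the scatter; no measured pair tells how a methoxy compares with a chloro there. Compound 4 is therefore expected near compound 2, with an estimated step of a 1.3-fold lower number from compound 2 to compound 4 (0.10 log units; within the scatter). Compound 4 is estimated at 2200 nM, with a range from 800 nM to 6000 nM.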

Compound 4, half-maximal inhibitory concentration: 2000 nM
Estimate against measurement, compound 4: 1.1-fold (0.04 log units) above, within the range that was stated.
By their numbers in this assay, from the lowest: compounds 3, 4, 2 and 1 (each within the scatter of the next, the first and the last beyond it).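

In this assay, among the compounds shown here, this is the first direct comparison of methoxy with chloro at this place (a 1.4-fold higher number from compound 3 to compound 4 (0.15 log units; within the scatter)), and the change stays within the scatter. The other two new steps (a 1.4-fold lower number from compound 2 to compound 4 (0.15 log units; within the scatter)) and (a 1.9-fold lower number from compound 1 to compound 4 (0.27 log units; within the scatter)) also stay within it, so 3-methoxyphenyl cannot be told apart from 2-chlorophenyl or 2-methylphenyl here. No measurement shown accounts for these small differences. The compounds shown leave open whether an amine, a nitrile or a carboxylic acid in place of the methoxy would move the number beyond the scatter.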